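Swapping the charged head group on a seven-carbon linker

The source may report more compounds than this note shows. Statements on the series, on what has been measured and on what is new or still open speak of the compounds shown alone.

Measured so far:
- compound 1, `Cc1ccc(-n2cc(C(=O)Nc3cc(F)cc(F)c3)c(=O)c3ccc(N(C)C)nc32)cc1OCCCCCCC[n+]1ccccc1`: 22.2%
- compound 2, `Cc1ccc(-n2cc(C(=O)Nc3cc(F)cc(F)c3)c(=O)c3ccc(N(C)C)nc32)cc1OCCCCCCC[N+]1(C)CCN(C)CC1`: 25%
- compound 3, `CC[N+]1(CCCCCCCOc2cc(-n3cc(C(=O)Nc4cc(F)cc(F)c4)c(=O)c4ccc(N(C)C)nc43)ccc2C)CCCC1`: 81.4%

All three share one core and differ only in the positively charged group at the far end of the chain. In an assay on LX2 cells for inhibition of COL1A1 promoter (Homo sapiens), read by a luciferase reporter, with a stated time of 24 h, tested at 50 uM (a higher number here means a stronger effect of the compound at the concentration tested, a lower number a weaker effect), compound 3 gives the highest of the three numbers. Its lead over compound 2 is shown by a number 56.4 percentage points higher from compound 2 to compound 3 (beyond the scatter), and over compound 1 by a number 59.2 percentage points higher from compound 1 to compound 3 (beyond the scatter), both beyond the scatter, while a number 2.8 percentage points higher from compound 1 to compound 2 (within the scatter) lies within it.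

Compound 4, `Cc1ccc(-n2cc(C(=O)Nc3cc(F)cc(F)c3)c(=O)c3ccc(N(C)C)nc32)cc1OCCCCCCC[N+](C)(C)C1CCCCC1`, keeps everything except that head group: a group of 9 heavy atoms (8 carbon, 1 nitrogen; one six-membered non-aromatic ring of carbon only) in place of a group of 7 heavy atoms (6 carbon, 1 nitrogen; one five-membered non-aromatic ring with 1 hetero atom), on a saturated chain carbon, seven bonds along the chain from an oxygen on an aromatic ring. Within the data shown here, no measured pair exchanges a five-membered non-aromatic ring for a six-membered ring of carbon only, so the two large steps into compound 3 are the only guide, and they show that this position can move the read-out strongly in either direction. Compound 4 is therefore expected to sit between the measured extremes, with the estimated step of a number 31.4 percentage points lower from compound 3 to compound 4 (beyond the scatter) pointing downward, and an expected value of 50% (range 20% to 85%).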

Compound 4, a percentage reported as inhibition, at one concentration (the size of the read-out at that concentration, not a potency): 61.7%
The estimate for compound 4 lay 11.7 percentage points below the measured number; the measured number falls inside the stated range.
By their numbers in this assay, from the lowest: compounds 1 and 2 (each within the scatter of the next); then compound 4; then compound 3.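

In this assay, compound 4 shows that a strong read-out is not tied to the head group of compound 3: a six-membered non-aromatic ring of carbon only also stands clear of both low compounds, with a number 36.7 percentage points higher from compound 2 to compound 4 (beyond the scatter) and a number 39.5 percentage points higher from compound 1 to compound 4 (beyond the scatter). The five-membered non-aromatic ring with 1 hetero atom still keeps a lead, with a number 19.7 percentage points lower from compound 3 to compound 4 (beyond the scatter), even though both groups carry a net charge of +1 and have no hydrogen-bond donors or acceptors, so these counts alone do not set the read-out. No measurement here explains these differences.

The compounds shown leave open whether a simple trimethylammonium group, with no ring at all, would hold the read-out. They also leave open how either of the two better head groups would behave on a longer chain.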